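Methylsulfanyl for methoxy: compound 1 to compound 3

The source may hold more compounds than are shown below. What is called first, only, known or untested is meant among the compounds shown, and "the series" means these compounds.

Among the measured compounds shown here, compound 1 `COc1cc(C)n(C)c(=O)c1CN1CCc2c(Cl)cc(-c3c(C)noc3C)c(Cl)c2C1=O` gives 11.6 nM in an assay on isolated protein for inhibition of histone-lysine N-methyltransferase EZH2 (Homo sapiens), read by filter binding, with a stated time of 1 h (on this read-out higher numbers stand for weaker inhibition and lower numbers for stronger inhibition), the higher of the two numbers so far. For the measured compounds named here, compound 2 `Cc1cc(C)c(CN2CCc3c(Cl)cc(-c4c(C)noc4C)c(Cl)c3C2=O)c(=O)[nH]1` gives 1 nM in this assay, a gap beyond the scatter, though the two compounds differ in more than one place and no single step joins them. Compound 3 `CSc1cc(C)n(C)c(=O)c1CN1CCc2c(Cl)cc(-c3c(C)noc3C)c(Cl)c2C1=O` carries methylsulfanyl in place of methoxy on an aromatic carbon, opposite the ring nitrogen of the shared core. Nothing measured isolates this swap. The step is expected to stay within the scatter, with at most a slight lean to a higher number, as a 1.2-fold higher number from compound 1 to compound 3 (0.08 log units; within the scatter) states. Compound 3 is estimated at 14 nM, range 5 nM to 40 nM.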

Compound 3, half-maximal inhibitory concentration: 1.3 nM
Beside the measured number, compound 3's estimate is 11-fold (1.03 log units) above it; measured number below the stated range.
By their numbers in this assay, from the lowest: compounds 2 and 3 (each within the scatter of the next); then compound 1.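

In this assay, methylsulfanyl in place of methoxy on this aromatic carbon gives an 8.9-fold lower number from compound 1 to compound 3 (0.95 log units; beyond the scatter), so the position opposite the ring nitrogen responds to a single-atom exchange of oxygen for sulfur. The two groups match in heavy atoms, hydrogen-bond donors and hydrogen-bond acceptors, so those counts do not separate them. Nothing available explains the step.

Open, on these data alone, is how this position responds to a longer chain such as ethylsulfanyl, or to an amine such as dimethylamino.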